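Swapping Fluoro for Nitro on the Aromatic Ring

This account rests on a few compounds, and the source may have more. Where it says the series, first, only, none or still open, it means among the compounds named here.

In a functional assay on HO8910 cells (Homo sapiens) for inhibition, read by MTT assay, with a stated time of 24 h, tested at 1 ug/mL (on this read-out lower numbers stand for less inhibition of growth and higher numbers for more inhibition of growth at the one concentration tested), compound 1 `O=C(CCCCC(S)CCS)Nc1cccc(Cl)c1` is recorded as "not active" (no number reported). Within the data shown here, compound 2 `O=C(CCCCC(S)CCS)Nc1ccc(F)cc1` gives 12.2%, the only actual number so far, so it cannot yet be ranked against a second value. Compound 3 `O=C(CCCCC(S)CCS)Nc1ccc([N+](=O)[O-])cc1` has nitro in place of fluoro on an aromatic carbon, para to a large group: nitro in place of fluoro on an aromatic carbon. Among the measured compounds shown here, no measured pair of closely related compounds shows how large such a change might be, so no shift beyond the usual scatter is expected. The expected step is a number 2.8 percentage points higher from compound 2 to compound 3 (within the scatter). Compound 3 is estimated at 15%, with an expected range of 3% to 32%.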

Compound 3, percent growth inhibition at one concentration: 0.76%
Compound 3: the middle estimate sits 14.2 percentage points above what was measured, outside the stated range (below it).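

In this assay, nitro in place of fluoro on the aromatic carbon para to a large group gives a number 11.4 percentage points lower from compound 2 to compound 3 (beyond the scatter), so this position can affect growth inhibition, and this swap reduces it. Compound 3 therefore offers no gain over compound 2 at the single concentration tested. Nothing shown here explains the drop. Still open, on these data alone, is how an amine or a carboxylic acid at this position would compare with fluoro and nitro. Whether any group here can lift growth inhibition above the level of compound 2 also remains unanswered.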